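The compounds below may be only part of what the source reports. "The series", "measured", "known", "first", "only" and "open" are said of these compounds alone.

Compound 1 `COc1cc2c(Oc3ccc(NC(=O)Nc4ccccc4C(F)(F)F)cc3)ccnc2cc1OCCCCCCC(=O)NO` stands highest of the two numbers in a functional assay on MCF7 cells (Homo sapiens) for antiproliferative activity, read by MTT assay; a higher number here means a weaker inhibitor, a lower number a stronger inhibitor: compound 1 gives 1080 nM. Among the compounds with values here, its nearest neighbour is compound 2 `COc1cc2c(Oc3ccc(NC(=O)NC4CCCCC4)cc3)ccnc2cc1OCCCCCCC(=O)NO`, which gives 600 nM; the step of a 1.8-fold lower number from compound 1 to compound 2 (0.26 log units; within the scatter) is the only measured change at the amide-type nitrogen. Compound 3 `COc1cc2c(Oc3ccc(NC(=O)NNC(=O)c4cccc(C)c4)cc3)ccnc2cc1OCCCCCCC(=O)NO` differs from compound 1 by ((3-methylphenyl)carbonyl)amino in place of 2-(trifluoromethyl)phenyl on an amide-type nitrogen. Within the data shown here, the one step at this nitrogen bears on it only loosely, as it swaps in a different group, and it lay within the scatter. No step beyond the scatter is therefore expected in this assay for compound 3, estimated at 1000 nM with a range of 400 nM to 2500 nM, meaning a 1.1-fold lower number from compound 1 to compound 3 (0.03 log units; within the scatter).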

Compound 3, half-maximal inhibitory concentration: 5830 nM
Compound 3: the middle estimate sits 5.8-fold (0.77 log units) below what was measured, outside the stated range (above it).
By their numbers in this assay, from the lowest: compounds 2 and 1 (each within the scatter of the next); then compound 3.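

In this assay, ((3-methylphenyl)carbonyl)amino on the amide-type nitrogen gives a step beyond the scatter against both earlier groups: 2-(trifluoromethyl)phenyl (a 5.4-fold higher number from compound 1 to compound 3 (0.73 log units; beyond the scatter)) and cyclohexyl (a 9.7-fold higher number from compound 2 to compound 3 (0.99 log units; beyond the scatter)). Within the data shown here, this position therefore responds to the group it carries, which the single earlier step, within the scatter, did not show. No measurement available here explains the rise.

On these data alone, whether it follows the added carbonyl and amino link or the ring remains open. A 3-methylphenyl group directly on the same nitrogen would separate the two.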